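A few compounds are considered here, and "the series" means these few. Any claim that something is new, unique, unknown or untested is made for them only; others in the source may bear on it.

Working notes on the series, read in a functional assay on HepG2 cells (Homo sapiens) for inhibition, read by MTT assay, with a stated time of 72 h; a higher number here means a weaker inhibitor, a lower number a stronger inhibitor. Compound 1 (`Cc1cccc(CN2CCc3ncn(COCc4ccccc4)c3/C(=C/c3ccccc3)C2=O)c1`) gives 34300 nM, compound 2 (`O=C1/C(=C\c2ccccc2)c2c(ncn2COCc2ccccc2)CCN1Cc1ccc(Cl)cc1`) gives 47900 nM, and compound 3 (`Cc1ccccc1CN1CCc2ncn(COCc3ccccc3)c2/C(=C/c2ccccc2)C1=O`) gives 53300 nM. Compound 1 therefore stands level with both neighbours, and the three values do not separate.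

The open change leads to compound 4 (`CC(C)(C)c1ccc(CN2CCc3ncn(COCc4ccccc4)c3/C(=C/c3ccccc3)C2=O)cc1`): 4-(tert-butyl)phenyl in place of 3-methylphenyl on a saturated chain carbon bound to an amide-type nitrogen in a ring. In words, 4-(tert-butyl)phenyl replaces 3-methylphenyl on a saturated chain carbon bound to an amide-type nitrogen in a ring.

Among the measured compounds shown here, three measured steps bear on this change. The swap to 4-chlorophenyl gave a 1.4-fold higher number from compound 1 to compound 2 (0.15 log units; within the scatter), the swap to 2-methylphenyl gave a 1.6-fold higher number from compound 1 to compound 3 (0.19 log units; within the scatter), and the swap between those two groups gave a 1.1-fold higher number from compound 2 to compound 3 (0.05 log units; within the scatter). All three aryl changes stay within the scatter, so no step beyond the scatter is expected in this assay. For the measured compounds named here, the 4-(tert-butyl)phenyl group itself has no measured precedent, which keeps the range wide.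

The estimated step is a 1.2-fold higher number from compound 1 to compound 4 (0.07 log units; within the scatter). For compound 4 the estimated value is 40000 nM, with an expected range of 18000 nM to 85000 nM.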

Compound 4, half-maximal inhibitory concentration: 18000 nM
The estimate for compound 4 lay 2.2-fold (0.35 log units) above the measured number, and the stated range covers the measured number.
By their numbers in this assay, from the lowest: compounds 4, 1, 2 and 3 (each within the scatter of the next, the first and the last beyond it).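

In this assay the earlier aryl swaps at this position all stayed within the scatter, whereas 4-(tert-butyl)phenyl gives the first separation, with a 3.0-fold lower number from compound 3 to compound 4 (0.47 log units; beyond the scatter) and a 2.7-fold lower number from compound 2 to compound 4 (0.43 log units; beyond the scatter). The separation is only partial, since a 1.9-fold lower number from compound 1 to compound 4 (0.28 log units; within the scatter), so compound 4 stands apart from compound 2 and compound 3 but level with compound 1. Nothing measured here accounts for these steps.

The compounds shown leave open how a phenyl group carrying a methoxy group, a carboxylic acid or a dimethylamino group would read on the same saturated chain carbon bound to an amide-type nitrogen in a ring. They also leave open whether an ethyl or isopropyl group in place of the tert-butyl would keep the separation from compound 2 and compound 3.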